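The source may hold more compounds than are shown below. What is called first, only, known or untested is meant among the compounds shown, and "the series" means these compounds.

Measured so far in a physicochemical assay for lipophilicity, at pH 7.4; on this read-out lower numbers stand for lower lipophilicity and higher numbers for higher lipophilicity:
- compound 1 `CC(C)CN(c1ccc(C#N)cc1)S(=O)(=O)c1ccc2c(c1)C(O)CC(C1CCOCC1)O2`: 3.07
- compound 2 `CC(C)CN(C1CCc2ccc(F)cc21)S(=O)(=O)c1ccc2c(c1)C(O)CC(C1CCOCC1)O2`: 3.94

Compound 2, at 3.94, is the higher of the two, clearly beyond the scatter. Compound 3 `CC(C)CN(c1ccccc1C(F)(F)F)S(=O)(=O)c1ccc2c(c1)C(O)CC(C1CCOCC1)O2` has not yet been measured. It carries 2-(trifluoromethyl)phenyl in place of 6-fluoro-2,3-dihydro-1H-inden-1-yl on a sulfonamide nitrogen. Going by the values given here, one measured step bears on this change, at the same nitrogen: a number 0.87 log units higher from compound 1 to compound 2 (beyond the scatter), a modest step. Compound 3 has a phenyl group there, as compound 1 does, but no nitrile, so only a small change without firm direction is expected in this assay, none beyond the scatter. The estimated step is a number 0.09 log units lower from compound 2 to compound 3 (within the scatter). For compound 3 the expected value is 3.85, with an estimated range of 3.4 to 4.3.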

Compound 3, distribution coefficient: 4.14
The estimate for compound 3 lay 0.29 log units below the measured number; the range from low to high includes it.
By their numbers in this assay, from the lowest: compound 1; then compounds 2 and 3 (each within the scatter of the next).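

At the sulfonamide nitrogen, this assay does not separate 2-(trifluoromethyl)phenyl from 6-fluoro-2,3-dihydro-1H-inden-1-yl (a number 0.20 log units higher from compound 2 to compound 3 (within the scatter)). Both compound 1 and compound 3 carry a six-membered aromatic ring on that nitrogen, yet exchanging 4-cyanophenyl for 2-(trifluoromethyl)phenyl gives a large step (a number 1.07 log units higher from compound 1 to compound 3 (beyond the scatter)), so the ring alone does not set the reading. Nothing available gives a cause for either step. The compounds shown leave open how a plain phenyl group, or a phenyl group bearing an amine or a carboxylic acid, would read on that nitrogen.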